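The source may hold more compounds than are shown below. What is called first, only, known or untested is meant among the compounds shown, and "the series" means these compounds.

Measured compounds in an assay on cells for activation of Cystic fibrosis transmembrane conductance regulator (Homo sapiens), read by fluorescence, with a stated time of 10 min; a lower number here means that less compound is needed, a higher number that more compound is needed for the effect:
compound 1 `O=c1c(-c2cccc([N+](=O)[O-])c2)nc2ccccc2n1Cc1ccccc1` — 9 nM
compound 2 `O=c1c(-c2ccc3nonc3c2)nc2ccccc2n1Cc1ccccc1` — 18 nM

Within the data shown here, compound 1 is one of only two compounds with a number in this assay. Among the measured compounds shown here, its single neighbour is compound 2, and the step from the one to the other, a 2.0-fold higher number from compound 1 to compound 2 (0.30 log units; within the scatter), does not separate them; both sit within the scatter of each other, so no order between them can be claimed. That step swaps the aryl group on the shared core and leaves the fused ring system of the core untouched.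

Compound 3 `O=c1c(-c2cccc([N+](=O)[O-])c2)nc2ccc(Cl)cc2n1Cc1ccccc1` differs from compound 1 by chloro in place of hydrogen on an aromatic carbon; that is, chloro in place of hydrogen on an aromatic carbon of the fused core. For the measured compounds named here, no measured step touches the core, so there is nothing in the data that speaks directly to this change. Going by the values given here, the one step that exists, from compound 1 to compound 2, concerns a different site and stays within the scatter. Among the compounds with values here, with no bearing step, the expectation for compound 3 is a step of a 1.1-fold higher number from compound 1 to compound 3 (0.05 log units; within the scatter), that is, none beyond the scatter. The estimate for compound 3 in this assay is 10 nM, with a range from 3 nM to 30 nM.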

Compound 3, half-maximal effective concentration: 760 nM
Compound 3: the middle estimate sits 76-fold (1.88 log units) below what was measured; the whole stated range lies below it.
By their numbers in this assay, from the lowest: compounds 1 and 2 (each within the scatter of the next); then compound 3.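

In this assay, among these compounds, putting chloro in place of hydrogen on this aromatic carbon of the fused core gives an 84-fold higher number from compound 1 to compound 3 (1.93 log units; beyond the scatter) and is the only step so far that lies beyond the scatter. Among the compounds shown here, the earlier step changed only the aryl group on the shared core and did not separate its two compounds (a 2.0-fold higher number from compound 1 to compound 2 (0.30 log units; within the scatter)), so the first measured change to the core itself shows that this carbon does not tolerate every substituent, even one adding a single heavy atom. No measurement at hand accounts for the size of this step.

With hydrogen and chloro as the only two groups shown here, it remains open whether the higher number is particular to chloro or would also follow from fluoro, methyl, methoxy or an amine on the same carbon. Also open, going by these compounds, are whether chloro at this place would bring a step of similar size alongside the aryl group of compound 2, and whether chloro elsewhere on the same six-membered ring of the core would behave in the same way.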